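The source may hold more compounds than are shown below. What is called first, only, known or untested is meant among the compounds shown, and "the series" means these compounds.

Compound 1 `COc1cc(/C=C/C(=O)c2cccc(-n3cc(-c4ccccc4)nn3)c2)ccc1O` gives 16800 nM in a functional assay on RAW264.7 cells (Mus musculus) for inhibition, with a stated time of 4 days; a lower number here means a stronger inhibitor, a higher number a weaker inhibitor. Compound 2 `COc1ccc(-c2cn(-c3cccc(C(=O)/C=C/c4ccc(O)c(OC)c4)c3)nn2)cc1` gives 7900 nM in this assay, and the step between the two is a 2.1-fold lower number from compound 1 to compound 2 (0.33 log units; beyond the scatter). Compound 3 `COc1ccc(/C=C/C(=O)c2cccc(-n3cc(-c4ccccc4)nn3)c2)cc1O` gives 1510 nM in this assay, the lowest number of the three measured, separated from compound 2 and from compound 1 by gaps beyond the scatter; the step from the parent is an 11-fold lower number from compound 1 to compound 3 (1.05 log units; beyond the scatter). Compound 4 `COc1ccc(-c2cn(-c3cccc(C(=O)/C=C/c4ccc(OC)c(O)c4)c3)nn2)cc1` has not yet been measured. Relative to compound 3 the change is methoxy in place of hydrogen on an aromatic carbon. Of the measured steps only one bears on it: the step of a 2.1-fold lower number from compound 1 to compound 2 (0.33 log units; beyond the scatter) is the same change, methoxy in place of hydrogen on an aromatic carbon, made on compound 1 rather than on compound 3. That step was modest but beyond the scatter, so a modest lowering of the number is expected here as well, a 2.0-fold lower number from compound 3 to compound 4 (0.30 log units; within the scatter). Compound 4 is therefore estimated at 750 nM in this assay, with a range of 300 nM to 1900 nM.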

Compound 4, half-maximal inhibitory concentration: 6290 nM
The estimate for compound 4 lay 8.4-fold (0.92 log units) below the measured number, outside the stated range (above it).
By their numbers in this assay, from the lowest: compound 3; then compounds 4 and 2 (each within the scatter of the next); then compound 1.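

Methoxy in place of hydrogen on the aromatic carbon para to a large group has no fixed direction in this assay: on the core of compound 3 it gives a 4.2-fold higher number from compound 3 to compound 4 (0.62 log units; beyond the scatter), and the gap to the same change on the core of compound 1 is beyond the scatter: the same change on two cores in this assay, a 2.1-fold lower number (0.33 log units; beyond the scatter) from compound 1 to compound 2 and a 4.2-fold higher number (0.62 log units; beyond the scatter) from compound 3 to compound 4, 8.9-fold (0.95 log units) apart, beyond the scatter of two such steps

The swap from 4-hydroxy-3-methoxyphenyl to 3-hydroxy-4-methoxyphenyl, read with the 4-methoxyphenyl in place, gives only a 1.3-fold lower number from compound 2 to compound 4 (0.10 log units; within the scatter), so the large lowering seen with phenyl does not carry over: the same change on two cores in this assay, an 11-fold lower number (1.05 log units; beyond the scatter) from compound 1 to compound 3 and a 1.3-fold lower number (0.10 log units; within the scatter) from compound 2 to compound 4, 8.9-fold (0.95 log units) apart, beyond the scatter of two such steps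

The two changes are therefore not additive across these four compounds, and compound 3, the only one pairing phenyl with 3-hydroxy-4-methoxyphenyl, stands lowest.

The compounds shown give no explanation for this dependence. Going by these compounds, whether fluoro, ethoxy or an amine at that aromatic carbon on the core of compound 3 would also raise the number remains open.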